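Methoxy in Place of Hydrogen: An Expected Step

This account rests on a few compounds, and the source may have more. Where it says the series, first, only, none or still open, it means among the compounds named here.

Measured so far:
compound 1, `CC1=CC[C@H](C(C)(C)N=C=S)CC1`, > 100000 nM
compound 2, `CC1=CC[C@H](C(C)(C)NC(=S)N/N=C/c2ccccc2)CC1`, 8800 nM

Compound 1 `CC1=CC[C@H](C(C)(C)N=C=S)CC1` gives in a functional assay on HT-29 cells (Homo sapiens) for inhibition, read by sulforhodamine B assay, with a stated time of 48 h (a higher number here means a weaker inhibitor of growth, a lower number a stronger inhibitor of growth), only a limit of the assay and no number, > 100000 nM. Compound 1 thus sits at the limit of > 100000 nM in this assay, at which 1 of the 2 values shown sits. Compound 2 `CC1=CC[C@H](C(C)(C)NC(=S)N/N=C/c2ccccc2)CC1` gives in this assay 8800 nM. Within the data shown here, compound 2 therefore carries the only actual number in the set; the other value is a limit, so no step between measured compounds can be drawn and nothing is known yet about how far a single change moves this read-out.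

Compound 3 `COc1ccc(/C=N/NC(=S)NC(C)(C)[C@H]2CC=C(C)CC2)cc1` differs from compound 2 by methoxy in place of hydrogen on an aromatic carbon. Among the measured compounds shown here, no measured pair shows a change of this kind, so the expectation rests only on the single number of compound 2 and on the small size of the change. The estimated step of a 1.3-fold lower number from compound 2 to compound 3 (0.10 log units; within the scatter) is expected to stay within the usual scatter, with no clear direction. Compound 3 is thus estimated at 7000 nM, with a range from 2500 nM to 25000 nM.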

Compound 3, concentration for 50% growth inhibition: 8400 nM
Beside the measured number, compound 3's estimate is 1.2-fold (0.08 log units) below it, within the range that was stated.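

With compound 3, the set gains its first step between two measured compounds, and so its first measure of how far a single change moves the read-out in this assay. Going from phenyl to 4-methoxyphenyl, with methoxy in place of hydrogen on an aromatic carbon para to a large group, gives a 1.0-fold lower number from compound 2 to compound 3 (0.02 log units; within the scatter), so this position of the six-membered aromatic ring accepts a group of 2 heavy atoms, with 1 hydrogen-bond acceptor, and the two compounds cannot be told apart in this read-out. Nothing measured here bears on why the read-out holds with this change.

As far as these compounds go, one step at one position says little about how the read-out responds to other groups there, and it remains open whether an amine, a carboxylic acid or a longer chain such as butoxy in the same place would also stay within the scatter or would move the number clearly in either direction. From the compounds shown here alone, it also remains open whether methoxy has the same lack of effect on compounds with a different group in place of the shared core, so this single pair supports no general pattern.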